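The compounds below may be only part of what the source reports. "The series", "measured", "known", "first", "only" and "open" are said of these compounds alone.

Compound 1 `O=C(Nc1cccc(Oc2ccccn2)c1)C1CCCN(C(=O)c2cc(C(F)(F)F)cc(C(F)(F)F)c2)C1` gives 0% in an ADME assay on PC-3 cells (Homo sapiens) for cytotoxicity, read by WST assay, tested at 100 uM; a lower number here means less inhibition, a higher number more inhibition at the concentration tested (going by the name of the read-out).
Compound 2 `O=C(Nc1ccc(Cl)cc1)C1CCCN(C(=O)c2cccc(-c3ccco3)c2)C1` gives 0% in this assay.
Compound 3 `CSc1cccc(C(=O)N2CCCC(C(=O)Nc3ccc(Cl)cc3)C2)c1` gives 0% in this assay.

Compound 1 stands level with compounds 2 and 3 at the digits shown: all three sit at the bottom of the scale in this assay. Within the data shown here, the only measured step between two compounds, no change at the digits printed from compound 2 to compound 3 (within the scatter), was flat, and it concerns a group on a different part of a different compound. Compound 4 `CCc1cccc(NC(=O)C2CCCN(C(=O)c3cc(C(F)(F)F)cc(C(F)(F)F)c3)C2)c1` differs from compound 1 by ethyl in place of (pyridin-2-yl)oxy on an aromatic carbon. Among the measured compounds shown here, no measured step touches either of these two groups, so nothing in the data points toward a change in one direction or the other, and the single flat step is the only guide. The step from compound 1 to compound 4 in this assay is therefore expected to be no change at the digits printed from compound 1 to compound 4 (within the scatter), nothing beyond the scatter. Compound 4 is estimated at 0%, within a range of 0% to 15%.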

Compound 4, a percentage reported as inhibition, at one concentration (the size of the read-out at that concentration, not a potency): 0%
Estimate against measurement, compound 4: no gap at the digits printed; the range from low to high includes it.
By their numbers in this assay, from the lowest: compounds 1, 2, 3 and 4 (each within the scatter of the next).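

In this assay, ethyl in place of (pyridin-2-yl)oxy on this aromatic carbon, meta to a large group, gives no change at the digits printed from compound 1 to compound 4 (within the scatter). Among these compounds, this is the first measured change at this position, and the reading stays at the bottom of the scale even with the pyridine ring and its hydrogen-bond acceptors gone, so the change brings no measurable inhibition. Nothing measured here offers an explanation for this flat result.

On these data alone, whether an amine, a carboxylic acid or a longer chain at this position would lift the reading above the bottom of the scale remains open.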